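Chloro Substitution on the Sulfamate Ring of Compound 1

A few compounds are considered here, and "the series" means these few. Any claim that something is new, unique, unknown or untested is made for them only; others in the source may bear on it.

Measured compounds:
compound 1 `Cc1ccccc1N(C)C(=O)c1ccc(-c2ccc(OS(N)(=O)=O)cc2)o1` — 15%
compound 2 `Cc1ccccc1N(C)C(=O)c1ccc(-c2ccccc2OS(N)(=O)=O)o1` — "nd" (no result reported)

In an assay on cytosol from placenta for inhibition of 17-beta-hydroxysteroid dehydrogenase type 1 (Homo sapiens), read by HPLC, with a stated time of 10 min, tested at 1 uM, in the presence of a further agent that is not named here (a lower number here means less inhibition, a higher number more inhibition at the concentration tested (going by the name of the read-out)), compound 1 gives 15%. For the measured compounds named here, this is the only number available; compound 2 was tested in this assay but gives "nd" (no result reported), so compound 1 stands alone and nothing can be said of how it compares with compound 2.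

Compound 3 `Cc1ccccc1N(C)C(=O)c1ccc(-c2ccc(OS(N)(=O)=O)c(Cl)c2)o1` differs from compound 1 in one place: chloro in place of hydrogen on an aromatic carbon. The new group sits on an aromatic carbon of a six-membered aromatic ring of carbon only, ortho to a sulfamoyloxy group and meta to a large group.

Going by the values given here, no step between measured compounds is available to calibrate this change, so the expectation rests on the structural change alone. A modest rise beyond the scatter is expected, from compound 1 to compound 3 a number 10 percentage points higher from compound 1 to compound 3 (within the scatter). Compound 3 is therefore estimated at 25%, with a range from 5% to 50%.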

Compound 3, a percentage reported as inhibition, at one concentration (the size of the read-out at that concentration, not a potency): 25%
Beside the measured number, compound 3's estimate shows no gap at the digits printed; the measured number falls inside the stated range.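

In this assay, for the compounds shown here, chloro in place of hydrogen on an aromatic carbon, ortho to a sulfamoyloxy group, gives a number 10 percentage points higher from compound 1 to compound 3 (within the scatter), the first step that can be read at this position. It shows that this position accepts a chloro group without a reading that can be told apart from that of the unsubstituted parent, so this single change leaves the inhibition at the concentration tested unresolved from the starting point. Nothing measured here bears on the reason for this result.

Going by these compounds, whether a different group at this place, such as fluoro, methoxy or an amine, would move the reading beyond the scatter remains open. Also open, on these data alone, is whether chloro would give a step of this size in a compound with the amide hydrogen in place of the amide methyl group.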